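The source may hold more compounds than are shown below. What is called first, only, known or untested is meant among the compounds shown, and "the series" means these compounds.

Two measured compounds set the scene. Compound 1 `Cc1cc(SC(C)(C)C)c(S(C)(=O)=O)cc1C(=O)N=C(N)N` gives 22 nM in a functional assay for inhibition of sodium/hydrogen exchanger (Oryctolagus cuniculus); on this read-out higher numbers stand for weaker inhibition and lower numbers for stronger inhibition. Compound 2 `COc1cc(C)c(C(=O)N=C(N)N)cc1S(C)(=O)=O` gives 16 nM in this assay. For the measured compounds named here, the single step between them, a 1.4-fold lower number from compound 1 to compound 2 (0.14 log units; within the scatter), comes from methoxy in place of (tert-butyl)sulfanyl on an aromatic carbon. Compound 2 thus holds the lower of the two numbers, but compound 1 lies within the usual scatter of it, so neither can be called the stronger inhibitor on this evidence.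

Compound 3 `Cc1cn(-c2cc(C)c(C(=O)N=C(N)N)cc2S(C)(=O)=O)cn1` has not yet been measured. It differs from compound 2 by 4-methyl-1H-imidazol-1-yl in place of methoxy on an aromatic carbon. Going by the values given here, the only measured step touches the same aromatic carbon: there, exchanging one substituent for another gave a 1.4-fold lower number from compound 1 to compound 2 (0.14 log units; within the scatter), a change too small to count. That is slim evidence, and the entering group brings a ring where the leaving group had none, but nothing seen so far points in either direction. The expected step is therefore a 1.3-fold higher number from compound 2 to compound 3 (0.10 log units; within the scatter), nothing beyond the scatter. Compound 3 is estimated at 20 nM, with a range from 6 nM to 65 nM.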

Compound 3, half-maximal inhibitory concentration: 28 nM
For compound 3 the middle estimate is 1.4-fold (0.15 log units) below the measured one; measured number inside the range.
By their numbers in this assay, from the lowest: compounds 2, 1 and 3 (each within the scatter of the next).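

For the compounds shown here, compound 3 puts a ring at the position ortho to a methylsulfonyl group, where the earlier compounds had none, and in this assay this gives a 1.8-fold higher number from compound 2 to compound 3 (0.24 log units; within the scatter) and a 1.3-fold higher number from compound 1 to compound 3 (0.10 log units; within the scatter). Neither step leaves the scatter, even though the change from methoxy to 4-methyl-1H-imidazol-1-yl raises the substituent from 2 heavy atoms to 6 and adds an aromatic ring, so this read-out cannot separate the three compounds, and a ring at this position has so far cost nothing measurable. Nothing measured alongside these numbers offers an explanation for how closely the three groups agree.

As far as these compounds go, what remains open is whether any group at this position can move the number beyond the scatter, for example a primary amine, a carboxylic acid or a longer alkyl chain, or the same ring without its methyl group. From the compounds shown here alone, the methyl and methylsulfonyl groups are the same in all three compounds, so the contribution of each to the read-out also remains unknown.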